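Aryl substituent step from compound 3 to compound 4

This account rests on a few compounds, and the source may have more. Where it says the series, first, only, none or still open, it means among the compounds named here.

Three thiosemicarbazones share one core. Compound 1 `COc1ccc(/C=N/NC(=S)NC(C)(C)[C@H]2CC=C(C)CC2)cc1` gives 8400 nM in a functional assay on HT-29 cells (Homo sapiens) for inhibition, read by sulforhodamine B assay, with a stated time of 48 h; on this read-out higher numbers stand for weaker inhibition of growth and lower numbers for stronger inhibition of growth. Compound 2 `CC1=CC[C@H](C(C)(C)NC(=S)N/N=C/c2ccccc2O)CC1` gives 10900 nM in this assay, and compound 3 `CC1=CC[C@H](C(C)(C)NC(=S)N/N=C/c2ccc(N(C)C)cc2)CC1` gives 46500 nM in this assay. Compound 3 thus holds the highest of the three numbers, beyond the scatter from both others: a 5.5-fold higher number from compound 1 to compound 3 (0.74 log units; beyond the scatter) lies beyond the scatter, whereas a 1.3-fold higher number from compound 1 to compound 2 (0.11 log units; within the scatter) stays within it.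

Compound 4 `CC1=CC[C@H](C(C)(C)NC(=S)N/N=C/c2ccc(F)cc2)CC1` is not yet measured. It differs from compound 3 by fluoro in place of dimethylamino on an aromatic carbon. Among the measured compounds shown here, no measured step introduces fluoro, so the only step that bears on it is the one that put dimethylamino in place of methoxy. For the measured compounds named here, because a 5.5-fold higher number from compound 1 to compound 3 (0.74 log units; beyond the scatter) raised the number modestly when dimethylamino entered, taking dimethylamino out again in compound 4 is expected to bring the number back toward that of compound 1, while the fluoro itself is a new element with no measured precedent here. For compound 4 the expected step is a 4.2-fold lower number from compound 3 to compound 4 (0.63 log units; beyond the scatter). Compound 4 is estimated at 11000 nM in this assay, with a range from 4000 nM to 30000 nM.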

Compound 4, concentration for 50% growth inhibition: > 100000 nM
Compound 4 was reported as a limit; the forecaster's own chance of this, stated with the estimate: 5%; middle value at least 9.0-fold (0.95 log units) away from the limit.
By their numbers in this assay, from the lowest: compounds 1 and 2 (each within the scatter of the next); then compound 3. At a limit, above all of these: compound 4.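

In this assay, compound 4 is reported only as a limit and not as a number: the limit of > 100000 nM in this assay, at which 1 of the 4 values shown sits. At this aromatic position, para to a large group, fluoro in place of dimethylamino gives an at least 2.1-fold higher number from compound 3 to compound 4 (0.33 log units; beyond the scatter), so removing dimethylamino does not return the number toward that of the methoxy compound, and dimethylamino is no longer the top of the series. Fluoro in place of methoxy gives an at least 11-fold higher number from compound 1 to compound 4 (1.07 log units; beyond the scatter), the only step in the series printed as large, while 4-fluorophenyl in place of 2-hydroxyphenyl gives an at least 9.1-fold higher number from compound 2 to compound 4 (0.96 log units; beyond the scatter).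

Going by these compounds, the true size of these three steps stays open, as each ends at a limit. On these data alone, whether chloro, hydroxy or a primary amine at this position would behave like fluoro or like methoxy also remains open.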